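The source may hold more compounds than are shown below. What is called first, only, known or untested is meant among the compounds shown, and "the series" means these compounds.

Compound 1 `Cn1cc(C2=C(c3n[nH]c4ncccc34)C(=O)NC2=O)c2ccccc21` gives > 100000 nM in a functional assay on A549 cells (Homo sapiens) for antiproliferative activity, read by MTT assay, with a stated time of 48 h (on this read-out higher numbers stand for weaker inhibition and lower numbers for stronger inhibition), which is a limit of the assay.
Compound 2 `Cn1cc(C2=C(c3nn(CCCn4cccc4)c4ncccc34)C(=O)N(c3ccccc3)C2=O)c2ccccc21` gives > 100000 nM in this assay, again a limit.
Compound 3 `COc1ccc(N2C(=O)C(c3cn(C)c4ccccc34)=C(c3nn(CCCN4CCCCC4)c4ncccc34)C2=O)cc1` gives 30300 nM in this assay.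

Compound 1 thus stands at the limit only, with no number of its own, and one further value shown is also a limit (the limit of > 100000 nM in this assay, at which 2 of the 3 values shown sit). Compound 4 `Cn1cc(C2=C(c3nn(CCCn4ccnc4)c4ncccc34)C(=O)NC2=O)c2ccccc21` differs from compound 1 by 3-(1H-imidazol-1-yl)propyl in place of hydrogen on an aromatic nitrogen. Compounds 2 and 3 both carry a propyl chain on that nitrogen, and of them only compound 3 returns a number, while compound 2 stays at the limit. The account therefore expects no step beyond the scatter in this assay, with the estimated at least 1.6-fold lower number from compound 1 to compound 4 (0.22 log units; that floor lies within the scatter) small. Compound 4 is expected to give about 60000 nM, between 15000 nM and 200000 nM.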

Compound 4, half-maximal inhibitory concentration: > 100000 nM
Compound 4 ended at the assay's limit; the forecaster's own chance of this, stated with the estimate: 50%; middle value at least 1.6-fold (0.22 log units) away from the limit.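

Compound 4 sits at a limit, as compound 1 does, so no step can be read between them: the limit of > 100000 nM in this assay, at which 3 of the 4 values shown sit.

From the compounds shown here alone, whether 3-(1H-imidazol-1-yl)propyl in place of hydrogen on that aromatic nitrogen shifts the value of compound 1 in this assay at all remains open.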